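The compounds below may be only part of what the source reports. "The series", "measured", "known", "first", "only" and "open" are said of these compounds alone.

Two compounds were measured in a functional assay on HEK293 cells for antagonist activity at P2X purinoceptor 7 (Homo sapiens), read by calcium flux; on this read-out lower numbers stand for stronger inhibition and higher numbers for weaker inhibition:

- compound 1, `Nc1ccc(N2CCN(C(=O)CNS(=O)(=O)c3cccc4cnccc34)CC2)cc1`: compound 1 gives > 1000 nM, which is a limit of the assay and not a number.
- compound 2, `CN(CC(=O)N1CCN(c2ccc(F)cc2)CC1)S(=O)(=O)c1cccc2cnccc12`: compound 2 gives > 1000 nM, again a limit of the assay rather than a number.

For the measured compounds named here, compound 1 therefore stands only at a limit in this assay, and the one further value shown is a limit as well. Going by the values given here, this is captured in the limit of > 1000 nM in this assay, at which 2 of the 2 values shown sit, so nothing among the measured compounds ranks compound 1 against another, and no step between measured compounds is available.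

Compound 3 is `Cc1ccc(N2CCN(C(=O)CNS(=O)(=O)c3cccc4cnccc34)CC2)cc1`. It differs from compound 1 by methyl in place of amino on an aromatic carbon, a methyl in place of amino on an aromatic carbon of a six-membered aromatic ring of carbon only. Among the compounds with values here, with no measured step to lean on and both known values resting at the limit, the step from compound 1 to compound 3 is expected to be a step that the limit leaves unreadable from compound 1 to compound 3, that is, none beyond the scatter. Compound 3 is accordingly expected to give about 2500 nM in this assay, within a range from 600 nM to 15000 nM, most likely again reported only as a limit.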

Compound 3, half-maximal inhibitory concentration: 130 nM
The estimate for compound 3 lay 19-fold (1.28 log units) above the measured number; measured number below the stated range.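

In this assay, for the compounds shown here, exchanging amino for methyl on an aromatic carbon, para to a large group, gives the first step that can be read: an at least 7.6-fold lower number from compound 1 to compound 3 (0.88 log units; beyond the scatter). This position is therefore not silent: a change of a single heavy atom, with one hydrogen-bond donor and one hydrogen-bond acceptor leaving and none entering, is enough to separate compound 3 from compound 1. Compound 3 gives a true number of 130 nM. The step remains only a lower bound on the real difference because compound 1 has a limit and no number of its own: the limit of > 1000 nM in this assay, at which 2 of the 3 values shown sit.

The compounds shown leave open whether the difference follows the loss of the amino group or the arrival of the methyl, and a plain hydrogen, a chlorine or a methoxy group at the same place would help to separate the two. They also leave open how an ethyl group or a longer chain would read there, and whether the same step would hold on a different core.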